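From a Substituted Aryl to Bare Phenyl on the Ring Nitrogen

The compounds below may be only part of what the source reports. "The series", "measured", "known", "first", "only" and "open" are said of these compounds alone.

Compound 1 `COc1ccc(C)cc1N1C(=O)CSC1c1cccc(C(=O)NCCCCc2ccccc2)c1` gives 30% in a functional assay on U2OS cells (Homo sapiens) for inhibition, read by CCK-8 assay, with a stated time of 72 h, tested at 1 uM; on this read-out lower numbers stand for less inhibition and higher numbers for more inhibition at the one concentration tested (going by the name of the read-out); compound 2 `COc1ccc(OC)c(N2C(=O)CSC2c2cccc(C(=O)NCCCCc3ccccc3)c2)c1` gives 1%; compound 3 `COc1ccc(F)cc1N1C(=O)CSC1c1cccc(C(=O)NCCCCc2ccccc2)c1` gives 32%.

Compound 3 stands highest of the three numbers. Its nearest neighbour is compound 1, with a number 2 percentage points higher from compound 1 to compound 3 (within the scatter), so these two cannot be ordered. Compound 2 lies far below, as a number 31 percentage points higher from compound 2 to compound 3 (beyond the scatter) shows.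

Compound 4 `O=C(NCCCCc1ccccc1)c1cccc(C2SCC(=O)N2c2ccccc2)c1` differs from compound 3 in one place: phenyl in place of 5-fluoro-2-methoxyphenyl on an amide-type nitrogen in a ring. Within the data shown here, no measured step removes this whole substituted ring in favour of a plain one. The two steps that touch the same ring, a number 2 percentage points higher from compound 1 to compound 3 (within the scatter) and a number 31 percentage points higher from compound 2 to compound 3 (beyond the scatter), only show that its substituents matter, so the expectation is uncertain and leans to a modest loss.

Compound 4 is therefore expected to give 22%, in a range from 3% to 42%. That estimate means a number 10 percentage points lower from compound 3 to compound 4 (within the scatter).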

Compound 4, a percentage reported as inhibition, at one concentration (the size of the read-out at that concentration, not a potency): 68%
Compound 4: middle estimate off by 46 percentage points, on the low side; the measured number lies above the stated range.
By their numbers in this assay, from the lowest: compound 2; then compounds 1 and 3 (each within the scatter of the next); then compound 4.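

Bare phenyl on the ring nitrogen gives more inhibition in this assay than every substituted ring shown, with a number 36 percentage points higher from compound 3 to compound 4 (beyond the scatter) and a number 38 percentage points higher from compound 1 to compound 4 (beyond the scatter) and a number 67 percentage points higher from compound 2 to compound 4 (beyond the scatter) as the three steps. The earlier compounds shown here compared substituted rings only with one another, so they could not show that all three fall well short of the unsubstituted ring at this position. Nothing measured here explains this gain.

The compounds shown leave open whether a lone fluoro or a lone methoxy on the phenyl already lowers the number, and whether an amine or a carboxylic acid there would raise it.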